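Aryl selenocyanate carbamates: growth inhibition notes

A few compounds are considered here, and "the series" means these few. Any claim that something is new, unique, unknown or untested is made for them only; others in the source may bear on it.

Measured so far:
compound 1 `CCCCOC(=O)Nc1ccc([Se]C#N)cc1` — 5300 nM
compound 2 `CCCCOC(=O)Nc1ccc([Se][Se]c2ccc(NC(=O)OCCCC)cc2)cc1` — 7200 nM

The series was assessed in an ADME assay on 184B5 cells (Homo sapiens) for cytotoxicity, read by MTT assay, with a stated time of 72 h; a lower number here means a stronger inhibitor of growth, a higher number a weaker inhibitor of growth. In this assay compound 1 gives 5300 nM. Compound 2, the diselenide that joins two of the same carbamate-bearing aryl units, gives 7200 nM. These two numbers sit within the scatter of each other, so nothing separates compound 1 from compound 2 on the data in hand; compound 1 simply serves as the reference point for the next step.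

The next compound, compound 3 `N#C[Se]c1ccc(NC(=O)Oc2ccccc2)cc1`, keeps the selenocyanate and the carbamate of compound 1 and changes only the ester side: phenyl in place of butyl on an oxygen next to a carbonyl group. Going by the values given here, no measured pair shows what this kind of exchange does in this assay, so the expectation rests on the two values above alone, which lie close together. The step is therefore expected to be small, in either direction, and not clearly beyond the scatter: a 1.2-fold lower number from compound 1 to compound 3 (0.07 log units; within the scatter). On that basis compound 3 is estimated at 4500 nM, with a range from 1500 nM to 14000 nM.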

Compound 3, concentration for 50% growth inhibition: 400 nM
The estimate for compound 3 lay 11-fold (1.05 log units) above the measured number, and the stated range ends above it.
By their numbers in this assay, from the lowest: compound 3; then compounds 1 and 2 (each within the scatter of the next).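

The ester side of the carbamate proves to be a sensitive place in this assay: with the selenocyanate and the carbamate kept, phenyl in place of butyl on an oxygen next to a carbonyl group gives a 13-fold lower number from compound 1 to compound 3 (1.12 log units; beyond the scatter). Going by these compounds alone, this is the first step to lie beyond the scatter, and it shows that growth inhibition here can shift widely through this group alone, with a chain without a ring leaving and a six-membered aromatic ring entering. Nothing in hand accounts for the step, so it stands as an observation on a single pair.

Within the data shown here, the one exchange does not separate the presence of the aromatic ring from the loss of the butyl chain, a question that cyclohexyl or benzyl on the same oxygen would address, and a chlorophenyl group would show whether the ring tolerates substitution. Also open, from the compounds shown here alone, is whether the same exchange carries over to the diselenide form represented by compound 2.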